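Side-chain variation on the shared core against ATM

This account rests on a few compounds, and the source may have more. Where it says the series, first, only, none or still open, it means among the compounds named here.

Three analogues of one core have been measured in an assay on MCF7 cells for inhibition of Serine-protein kinase ATM (Homo sapiens), read by immunofluorescence, with a stated time of 1 h; on this read-out lower numbers stand for stronger inhibition and higher numbers for weaker inhibition. Compound 1 `COc1cc2ncnc(-n3nc(-c4ccccn4)nc3N)c2cc1OCc1ccccc1` gives 8600 nM, compound 2 `COCCOc1cc2c(-n3nc(-c4ccccn4)nc3N)ncnc2cc1OC` gives 1200 nM and compound 3 `COc1cc2ncnc(-n3nc(-c4ccccn4)nc3N)c2cc1OCCCNC(=O)CN1C[C@@H](C)O[C@@H](C)C1` gives 1700 nM. Among the compounds with values here, the only single-point step so far, a 7.2-fold lower number from compound 1 to compound 2 (0.86 log units; beyond the scatter), concerns the group on the saturated chain carbon bound to the oxygen on the aromatic ring. Compound 3 sits second highest of the three numbers; its value and that of compound 2 lie within the scatter of each other, while compound 1 stands well beyond it.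

Compound 4 `COc1cc2ncnc(-n3nc(-c4ccccn4)nc3N)c2cc1OCCCCNC(=O)OC(C)(C)C` differs from compound 3 by ((tert-butoxycarbonyl)amino)methyl in place of (((2,6-dimethylmorpholin-4-yl)methyl)carbonyl)amino on a saturated chain carbon, three bonds along the chain from an oxygen on an aromatic ring. Within the data shown here, no measured step covers this exchange; the step from compound 1 to compound 2 touches the same side chain only at its first carbon. The expected step from compound 3 to compound 4 in this assay is therefore small, a 1.2-fold higher number from compound 3 to compound 4 (0.07 log units; within the scatter), in no firm direction. Compound 4 is estimated at 2000 nM, between 700 nM and 6000 nM.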

Compound 4, half-maximal inhibitory concentration: 800 nM
For compound 4 the middle estimate is 2.5-fold (0.40 log units) above the measured one; measured number inside the range.
By their numbers in this assay, from the lowest: compounds 4, 2 and 3 (each within the scatter of the next, the first and the last beyond it); then compound 1.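

At this carbon of the side chain, a group without a ring serves at least as well in this assay: a 2.1-fold lower number from compound 3 to compound 4 (0.33 log units; beyond the scatter), with ((tert-butoxycarbonyl)amino)methyl entering. The other two steps separate the groups on the chain: a 1.5-fold lower number from compound 2 to compound 4 (0.18 log units; within the scatter) leaves 2-((tert-butoxycarbonyl)amino)ethyl and methoxy unresolved, while an 11-fold lower number from compound 1 to compound 4 (1.03 log units; beyond the scatter) sets 3-((tert-butoxycarbonyl)amino)propyl clearly apart from phenyl. No measurement available here accounts for these steps. Open, from the compounds shown here alone, is whether a primary amine or a carboxylic acid at the end of this chain, or a longer chain, would hold this level.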